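This account rests on a few compounds, and the source may have more. Where it says the series, first, only, none or still open, it means among the compounds named here.

Measured in a functional assay on K562 cells (Homo sapiens) for antiproliferative activity, read by CellTiter-Glo, with a stated time of 72 h; on this read-out higher numbers stand for an effect only at larger amounts of compound and lower numbers for an effect already at smaller amounts:
Compound 1 `CCCCCNc1ncnc2c1ncn2[C@@H]1O[C@H](COS(N)(=O)=O)[C@@H](O)[C@H]1O`: 181 nM
Compound 2 `CN(Cc1ccco1)c1ncnc2c1ncn2[C@@H]1O[C@H](COS(N)(=O)=O)[C@@H](O)[C@H]1O`: > 1000 nM (a limit, not a number)

Compound 2 gives no exact number, and its result stands at the limit of > 1000 nM in this assay, at which 1 of the 2 values shown sits. Compound 3 `NS(=O)(=O)OC[C@H]1O[C@@H](n2cnc3c(N4CCC5CCCCC5C4)ncnc32)[C@H](O)[C@@H]1O` changes the same place on the shared core: a group of 10 heavy atoms (9 carbon, 1 nitrogen; one six-membered non-aromatic ring of carbon only, one six-membered non-aromatic ring with 1 hetero atom) in place of a group of 8 heavy atoms (6 carbon, 1 nitrogen, 1 oxygen; one five-membered aromatic ring with 1 hetero atom), on an aromatic carbon. Going by the values given here, the only measured step at this place is an at least 5.5-fold higher number from compound 1 to compound 2 (0.74 log units; beyond the scatter). It shows that this place can matter, but it does not predict the effect of the new group, so no clear step in this assay is expected in either direction. The expected change is a number no higher from compound 2 to compound 3 (the limit leaves the size open). For compound 3, the estimate is 1000 nM, with an expected range from 250 nM to 4000 nM.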

Compound 3, half-maximal effective concentration: > 1000 nM
Compound 3 gave a limit, no number; the forecaster's own chance of this, stated with the estimate: 50%; the middle value sits exactly at the limit.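

In this assay, replacing pentylamino with the group carrying two six-membered non-aromatic rings gives an at least 5.5-fold higher number from compound 1 to compound 3 (0.74 log units; beyond the scatter). The furan ring is therefore not needed for a step of this kind, since compound 3 lacks it and still sits on the same side of compound 1 as compound 2 does. The step between compound 2 and compound 3 cannot be read, since both results are limits: the limit of > 1000 nM in this assay, at which 2 of the 3 values shown sit.

The compounds shown leave open what in the pentylamino group matters. A shorter butylamino chain, a longer hexylamino chain or a cyclohexylamino group at this place would help to separate chain length from ring.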